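Fluoro removal on the biphenyl arm of compound 1

A few compounds are considered here, and "the series" means these few. Any claim that something is new, unique, unknown or untested is made for them only; others in the source may bear on it.

Of the compounds shown here, two have been measured in an assay on cells for inhibition of Voltage-dependent T-type calcium channel subunit alpha-1I (Homo sapiens), read by patch clamp, tested at 10 uM; a lower number here means less inhibition, a higher number more inhibition at the concentration tested (going by the name of the read-out). Compound 1 `CN(C)CCCCCSC1=Nc2ccccc2C(CC(=O)NCc2ccccc2)N1c1ccc(-c2ccc(F)cc2)cc1` gives 66.7% in this assay, the higher of the two numbers. Compound 2 `O=C(CC1c2ccccc2N=C(SCCCCCN2CCCC2)N1c1ccc(-c2ccccc2)cc1)NCc1ccc(F)cc1` gives 55.9% in this assay, a number set apart from compound 1 by a gap beyond the usual scatter. Among the compounds with values here, compound 2 differs from compound 1 in more than one place, so no single step between measured compounds is at hand to guide the next change.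

Compound 3 `CN(C)CCCCCSC1=Nc2ccccc2C(CC(=O)NCc2ccccc2)N1c1ccc(-c2ccccc2)cc1` is the analogue of compound 1 carrying the difference (hydrogen in place of fluoro on an aromatic carbon). The change sits on an aromatic carbon of a six-membered aromatic ring of carbon only, para to a large group; cut one bond further out it reads as 4-fluorophenyl to phenyl.

Within the data shown here, no measured pair isolates this change. The step from compound 1 to compound 3 is expected to be small, most likely a modest loss of inhibition or nothing beyond the scatter, as a number 6.7 percentage points lower from compound 1 to compound 3 (within the scatter). Compound 3 is accordingly estimated at 60% in this assay, within 42% to 76%.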

Compound 3, a percentage reported as inhibition, at one concentration (the size of the read-out at that concentration, not a potency): 85.6%
The estimate for compound 3 lay 25.6 percentage points below the measured number; the measured number lies above the stated range.
By their numbers in this assay, from the lowest: compound 2; then compound 1; then compound 3.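

In this assay, hydrogen in place of fluoro on an aromatic carbon, para to a large group, gives a number 18.9 percentage points higher from compound 1 to compound 3 (beyond the scatter), the only comparison among the compounds shown that isolates a single change. The fluoro is therefore not needed for inhibition on this side chain of compound 1: the plain phenyl retains more inhibition than the 4-fluorophenyl, although this is a reading at one concentration and not a potency. Nothing at hand explains the direction of this step.

On these data alone, with only hydrogen and fluoro compared at this aromatic carbon, it remains open whether the step reflects something specific to fluoro or would also appear with chloro, methyl, methoxy or a nitrile in the same place. As far as these compounds go, it is also open whether the same step would appear with a pyrrolidine in place of the dimethylamine at the end of the chain, or with a fluoro on the benzyl group of the amide.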